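The compounds below may be only part of what the source reports. "The series", "measured", "known", "first", "only" and "open" are said of these compounds alone.

Measured compounds in a functional assay for inhibition, with Cavia porcellus as the target; on this read-out higher numbers stand for an effect only at larger amounts of compound and lower numbers for an effect already at smaller amounts:
Compound 1 `CCC(C)OC(=O)c1cc(CN2CCCC2)c(O)c(CN2CCCC2)c1`: in this assay compound 1 gives 6.7 ug/mL.
Compound 2 `CC(C)COC(=O)c1cc(CN2CCCC2)c(O)c(CN2CCCC2)c1`: in this assay compound 2 gives 2.3 ug/mL.

Among the compounds with values here, compound 2 stands at the lowest of the two numbers, and its only neighbour is compound 1. Within the data shown here, the single measured step is a 2.9-fold lower number from compound 1 to compound 2 (0.46 log units; beyond the scatter), a change confined to the alkyl group on the ester oxygen, and it is modest in size.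

Compound 3 `O=C(Nc1ccccc1)c1cc(CN2CCCC2)c(O)c(CN2CCCC2)c1` differs from compound 2 in one place: anilino in place of isobutoxy on a carbonyl carbon. Among the measured compounds shown here, no measured step bears on an exchange of this kind, since the one step known concerns only two alkyl groups on the same ester oxygen; the replacement of the whole isobutoxy group by anilino on the carbonyl carbon is untested. The expectation for compound 3 can therefore rest only on the observation that the ester alkyl variation moved the number modestly. For compound 3 in this assay the estimate is 4 ug/mL, with a range from 1 ug/mL to 16 ug/mL. This estimate corresponds to a 1.7-fold higher number from compound 2 to compound 3 (0.24 log units; within the scatter), a step expected to be of uncertain direction and not clearly beyond the scatter.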

Compound 3, concentration for half-maximal effect: 11 ug/mL
Compound 3: middle estimate off by 2.8-fold (0.44 log units), on the low side; the range from low to high includes it.
By their numbers in this assay, from the lowest: compound 2; then compounds 1 and 3 (each within the scatter of the next).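

In this assay, the carbonyl carbon is shown for the first time carrying something other than an alkoxy group, and the phenylcarbamoyl compound still gives a measurable effect. Anilino in place of isobutoxy gives a 4.8-fold higher number from compound 2 to compound 3 (0.68 log units; beyond the scatter) while anilino in place of sec-butoxy gives a 1.6-fold higher number from compound 1 to compound 3 (0.22 log units; within the scatter) so the same exchange reads as a clear change against one ester and as no distinguishable change against the other, leaving the isobutyl ester alone clear of both neighbours. Nothing available on these compounds accounts for this outcome.

The three compounds leave open whether the shift belongs to the amide link or to the aromatic ring of the anilino group, since the two enter together and an isobutylamino group on the same carbonyl carbon would separate them from the alkyl part held by compound 2. From the compounds shown here alone, how far the position tolerates other replacements, such as a cyclohexylamino group or a free carboxylic acid, also remains open, as does whether the pyrrolidine-bearing remainder of the shared core responds in the same way.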